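This account rests on a few compounds, and the source may have more. Where it says the series, first, only, none or still open, it means among the compounds named here.

Three esters sharing the core of compound 1 have been tested in a functional assay on A549 cells (Homo sapiens) for antiproliferative activity, read by MTT assay, with a stated time of 48 h; on this read-out lower numbers stand for stronger inhibition and higher numbers for weaker inhibition. Compound 1, `C/C(=C\CC/C(C)=C/CC[C@@H]1[C@@]2(C)CCC(=O)C(C)(C)[C@H]2CC[C@@]1(C)O)CC/C=C(\C)C(=O)OCc1cn(-c2ccccc2[N+](=O)[O-])nn1`, carrying a 2-nitrophenyl on an aromatic nitrogen, gives > 150000 nM, which is a limit and not a number. Compound 2, `C/C(=C\CC/C(C)=C/CC[C@@H]1[C@@]2(C)CCC(=O)C(C)(C)[C@H]2CC[C@@]1(C)O)CC/C=C(\C)C(=O)OCc1cn(-c2cccc([N+](=O)[O-])c2)nn1`, carrying a 3-nitrophenyl there, gives > 150000 nM, again a limit. Compound 3, `C/C(=C\CC/C(C)=C/CC[C@@H]1[C@@]2(C)CCC(=O)C(C)(C)[C@H]2CC[C@@]1(C)O)CC/C=C(\C)C(=O)OCc1cn(-c2ccccc2)nn1`, the plain phenyl member, gives > 150000 nM, also only a limit. So compound 3 has no measured potency, and it shares its position with the other two: the limit of > 150000 nM in this assay, at which 3 of the 3 values shown sit.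

Compound 4, `C/C(=C\CC/C(C)=C/CC[C@@H]1[C@@]2(C)CCC(=O)C(C)(C)[C@H]2CC[C@@]1(C)O)CC/C=C(\C)C(=O)OCc1cn(-c2cccc(F)c2)nn1`, departs from compound 3 by one change: fluoro in place of hydrogen on an aromatic carbon. This places fluoro in place of hydrogen on an aromatic carbon, meta to a large group. The measured steps closest to this change are a step that the two limits leave unreadable from compound 2 to compound 3 and a step that the two limits leave unreadable from compound 1 to compound 3, both on the same ring, while a step that the two limits leave unreadable from compound 1 to compound 2 moves the nitro group. None of the three has a readable size, so none gives a direction in this assay. Neither nitro placement nor its removal brought a number into view, so no step beyond the scatter is expected, and another limit is the likeliest report. The estimated step is a step that the limit leaves unreadable from compound 3 to compound 4. Compound 4 is expected at 170000 nM, with an estimated range from 90000 nM to 300000 nM.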

Compound 4, half-maximal inhibitory concentration: 124000 nM
Beside the measured number, compound 4's estimate is 1.4-fold (0.14 log units) above it; measured number inside the range.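

In this assay, compound 4 gives 124000 nM, the first number rather than a limit among the compounds shown, so this position on the ring now has a readable value. Fluoro in place of hydrogen is an at least 1.2-fold lower number from compound 3 to compound 4 (0.08 log units; that floor lies within the scatter), fluoro in place of nitro is an at least 1.2-fold lower number from compound 2 to compound 4 (0.08 log units; that floor lies within the scatter), and 3-fluorophenyl in place of 2-nitrophenyl is an at least 1.2-fold lower number from compound 1 to compound 4 (0.08 log units; that floor lies within the scatter). Each of these steps is only a floor, so the number alone does not establish that compound 4 differs in a real way from the other three compounds, which all stay at a limit: the limit of > 150000 nM in this assay, at which 3 of the 4 values shown sit.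

From the compounds shown here alone, compound 1, compound 2 and compound 3 have no number, so the true size of all three steps remains unknown, and it stays open whether fluoro at this place does anything beyond the scatter. Going by these compounds, it also remains open whether chloro, methoxy or an amine on the same aromatic carbon would give a number in this assay, and whether any such group would give a step whose floor lies beyond the scatter.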